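A few compounds are considered here, and "the series" means these few. Any claim that something is new, unique, unknown or untested is made for them only; others in the source may bear on it.

Measured in a functional assay on MCF7 cells (Homo sapiens) for inhibition, read by sulforhodamine B assay; a lower number here means a stronger inhibitor of growth, a higher number a weaker inhibitor of growth:
- compound 1 (`Cc1ccc2[nH]c(-c3ccc(-c4ccc(-c5ccccc5)cc4)cc3)nc2c1`) : 31600 nM
- compound 2 (`Cc1ccc2[nH]c(-c3ccc(-c4ccc(-c5ccc(F)cc5)cc4)cc3)nc2c1`) : 30200 nM

The two values lie within the scatter of each other, so compound 2 cannot be separated from compound 1 in this assay.

The next step leads to compound 3 (`Cc1ccc2[nH]c(-c3ccc(-c4ccc(-c5ccc(O)cc5)cc4)cc3)nc2c1`), which has hydroxy in place of fluoro on an aromatic carbon, para to a large group (hydroxy in place of fluoro on an aromatic carbon). Among the compounds with values here, only one measured step bears on this change: a 1.0-fold lower number from compound 1 to compound 2 (0.02 log units; within the scatter), with fluoro in place of hydrogen on an aromatic carbon. That step is within the scatter. Within the data shown here, it is only indirect evidence, as neither measured compound carries hydroxy and no measured step covers the exchange of fluoro for hydroxy.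

On this limited basis, no step beyond the scatter is expected in this assay, and no direction is firmly indicated. The expected step is a 1.2-fold lower number from compound 2 to compound 3 (0.08 log units; within the scatter). For compound 3 the estimated value is 25000 nM, with an expected range from 7000 nM to 60000 nM. Among the measured compounds shown here, the range is kept wide, given the single step available.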

Compound 3, concentration for 50% growth inhibition: 12100 nM
Compound 3: middle estimate off by 2.1-fold (0.32 log units), on the high side; the measured number falls inside the stated range.
By their numbers in this assay, from the lowest: compound 3; then compounds 2 and 1 (each within the scatter of the next).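

Notes on the series: in this assay, this place on an aromatic carbon, para to a large group, now proves responsive to substitution, since the exchange of fluoro for hydroxy gives a 2.5-fold lower number from compound 2 to compound 3 (0.40 log units; beyond the scatter), a modest step beyond the scatter, whereas the earlier exchange of hydrogen for fluoro gave only a 1.0-fold lower number from compound 1 to compound 2 (0.02 log units; within the scatter). Hydroxy in place of hydrogen gives a closely similar result, a 2.6-fold lower number from compound 1 to compound 3 (0.42 log units; beyond the scatter), so in these three compounds the step follows the entry of hydroxy, whichever of the two smaller substituents it replaces, and compound 1 and compound 2 remain within the scatter of each other. No measurement available here accounts for the step.

Open, as far as these compounds go, is whether the step is particular to hydroxy or would also appear with an amine, a carboxylic acid or a methoxy group at this place. Open too, from the compounds shown here alone, is how far the step carries over to the rest of the series, as the three compounds share one core and differ only at this single place, which leaves untested any change to the core itself or the effect of hydroxy placed elsewhere.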